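A few compounds are considered here, and "the series" means these few. Any claim that something is new, unique, unknown or untested is made for them only; others in the source may bear on it.

In an ADME assay on Vero cells (Chlorocebus sabaeus) for cytotoxicity, read by CellTiter-Glo, with a stated time of 72 h (a higher number here means that more compound is tolerated, a lower number that less compound is tolerated), compound 1 `CC(C)(C)Nc1n[n+]([O-])c2ccccc2[n+]1[O-]` gives 8 ug/mL and stands level with compound 2 `[O-][n+]1nc(NC2CCCCC2)[n+]([O-])c2ccccc21` at 8.9 ug/mL while compound 3 `COCC(C)Nc1n[n+]([O-])c2cc(Cl)ccc2[n+]1[O-]` sits lower at 2.6 ug/mL with more than one structural difference. Compound 4 `CCN(CC)c1n[n+]([O-])c2ccccc2[n+]1[O-]` has not been measured. It has the same atoms as compound 1, joined differently, with diethylamino in place of (tert-butyl)amino on an aromatic carbon. Going by the values given here, the one measured step that bears on this is a 1.1-fold higher number from compound 1 to compound 2 (0.05 log units; within the scatter) and it also swaps the group on the amine nitrogen. Among the compounds with values here, no measured compound carries diethylamino, so this is only a loose guide, and no step beyond the scatter is expected in this assay for this change. The expected change is a 1.1-fold lower number from compound 1 to compound 4 (0.06 log units; within the scatter) and would stay small. Compound 4 is estimated at 7 ug/mL (expected range 3 ug/mL to 16 ug/mL).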

Compound 4, half-maximal cytotoxic concentration: 12 ug/mL
The estimate for compound 4 lay 1.7-fold (0.23 log units) below the measured number, and the stated range covers the measured number.
By their numbers in this assay, from the lowest: compound 3; then compounds 1, 2 and 4 (each within the scatter of the next).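

In this assay diethylamino in place of (tert-butyl)amino on the aromatic carbon gives a 1.5-fold higher number from compound 1 to compound 4 (0.18 log units; within the scatter) and so stays within the scatter. Unlike compound 2, which keeps the hydrogen-bond donor on that nitrogen, compound 4 has none, and in this pair losing it brings no step beyond the scatter. Nothing available explains this result.

As far as these compounds go, whether a smaller group such as dimethylamino or a ring amine such as morpholine would read the same on the shared core remains open. So does whether diethylamino would read the same alongside the chlorine of compound 3.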